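Cyano in Place of Bromo on a Shared Amide Core

The source may hold more compounds than are shown below. What is called first, only, known or untested is meant among the compounds shown, and "the series" means these compounds.

Three compounds share one core and differ only in the group on the amide-type nitrogen. Compound 1 `COc1ccc(C(=O)Nc2ccccn2)cc1OC1CCCC1` gives 1000 nM in an assay on isolated protein for inhibition of phosphodiesterase 4A (Sus scrofa); on this read-out lower numbers stand for stronger inhibition and higher numbers for weaker inhibition. Compound 2 `COc1ccc(C(=O)NC2(C)C=C(C)ON2)cc1OC1CCCC1` gives 450 nM in this assay, and the step of a 2.2-fold lower number from compound 1 to compound 2 (0.35 log units; beyond the scatter) is modest. Compound 3 `COc1ccc(C(=O)Nc2c(C)nsc2Br)cc1OC1CCCC1` gives 500 nM in this assay; the steps of a 2.0-fold lower number from compound 1 to compound 3 (0.30 log units; within the scatter) and a 1.1-fold higher number from compound 2 to compound 3 (0.05 log units; within the scatter) both lie within the scatter, so compound 3 cannot be ordered against either of the other two, although its number is the second highest of the three.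

Compound 4 `COc1ccc(C(=O)Nc2c(C)nsc2C#N)cc1OC1CCCC1` differs from compound 3 in one place: cyano in place of bromo on an aromatic carbon, on an aromatic carbon of a five-membered aromatic ring with 1 nitrogen and 1 sulfur, next to the ring sulfur. For the measured compounds named here, none of the measured steps bears directly on this exchange: each of them replaces the whole group on the amide-type nitrogen, and none alters a single substituent on that five-membered aromatic ring. Those steps were all small, ranging from within the scatter to modest. With no step of this kind in hand, the expectation is that the step of no change at the digits printed from compound 3 to compound 4 (within the scatter) stays within the scatter. Compound 4 is therefore expected to give about 500 nM in this assay, with a range from 200 nM to 1300 nM.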

Compound 4, half-maximal inhibitory concentration: 200 nM
For compound 4 the middle estimate is 2.5-fold (0.40 log units) above the measured one; the range from low to high includes it.
By their numbers in this assay, from the lowest: compound 4; then compounds 2, 3 and 1 (each within the scatter of the next, the first and the last beyond it).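

For the compounds shown here, exchanging bromo for cyano on the aromatic carbon next to the ring sulfur gives, in this assay, a 2.5-fold lower number from compound 3 to compound 4 (0.40 log units; beyond the scatter), and this is the first change of a single substituent on this five-membered aromatic ring, showing that the number responds at this position. Compound 3 could not be separated from either of the other two, whereas the cyano-bearing group on the amide-type nitrogen gives both a 2.3-fold lower number from compound 2 to compound 4 (0.35 log units; beyond the scatter) and a 5.0-fold lower number from compound 1 to compound 4 (0.70 log units; beyond the scatter), so the exchange of this one substituent is enough to set the 5-cyano-3-methyl-1,2-thiazol-4-yl group apart from the other groups on that nitrogen. Nothing measured here accounts for why the number falls with this exchange, so the step stands as an observation only.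

On these data alone, whether the step is particular to cyano, or whether chloro, methyl or an amine on the same aromatic carbon would give a similar number, stays open. Also open, as far as these compounds go, is how a carboxylic acid at this carbon, or a longer chain in place of the methyl group on the ring, would read in this assay.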